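Ring closure on the nitrogen substituent of a dibromophenyl imidazoline

The source may hold more compounds than are shown below. What is called first, only, known or untested is meant among the compounds shown, and "the series" means these compounds.

Measured compounds:
compound 1 `CCCCN(C1=NCCN1)c1c(Br)cccc1Br` — -2.5
compound 2 `Brc1cccc(Br)c1N(CC1CCC1)C1=NCCN1` — -0.06

Within the data shown here, in a physicochemical assay for lipophilicity (a lower number here means a more polar compound, a higher number a more lipophilic compound), compound 1 gives -2.5, the lowest of the two numbers measured so far. Among the measured compounds shown here, the nearest measured neighbour is compound 2, which in this assay gives -0.06; the only step measured so far, a number 2.44 log units higher from compound 1 to compound 2 (beyond the scatter), is large and well beyond the scatter.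

The unmeasured compound 3 `Brc1cccc(Br)c1N(C1=NCCN1)C1CCCCC1` shares the core of compound 1 and differs from it in one place: cyclohexyl in place of butyl on a nitrogen on an aromatic ring. For the measured compounds named here, the measured step from compound 1 to compound 2 also adds ring carbon to the group on that nitrogen, and it raised the value strongly, so it is the one step that bears on this change. Compound 3 adds more carbon than compound 2 does, and a step in the same direction, at least as large, is therefore expected: a number 2.80 log units higher from compound 1 to compound 3 (beyond the scatter). For compound 3 the value in this assay is estimated at 0.3, with a likely range from -1 to 1.5.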

Compound 3, distribution coefficient: 0.14
Compound 3: the middle estimate sits 0.16 log units above what was measured; the range from low to high includes it.
By their numbers in this assay, from the lowest: compound 1; then compounds 2 and 3 (each within the scatter of the next).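

In this assay, cyclohexyl in place of butyl on the nitrogen gives a number 2.64 log units higher from compound 1 to compound 3 (beyond the scatter), so the large distance from compound 1 seen with compound 2 now recurs with a second ring-bearing group on this nitrogen. Cyclohexyl in place of cyclobutylmethyl gives a number 0.20 log units higher from compound 2 to compound 3 (within the scatter), so this change separates compound 2 and compound 3 by no more than the scatter, and the two different ring-bearing groups cannot be told apart in this assay. Among these three compounds, the butyl group of compound 1 alone stands apart from the others, but nothing shown here explains why the value moves so far at this position.

With compound 1 as the only open-chain example, the compounds shown cannot separate the presence of a ring from the number of carbons in the group, and a longer chain such as hexyl on the same nitrogen would bear directly on that question. They also leave open how this assay would respond to a group carrying a heteroatom, such as a hydroxyl on the cyclohexyl ring or a tetrahydropyranyl ring in its place.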